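The compounds below may be only part of what the source reports. "The series", "measured", "known", "first", "only" and "open" are said of these compounds alone.

Three compounds have been measured in an ADME assay on microsomes from liver (Homo sapiens) for metabolic stability, with a stated time of 60 min, tested at 1 uM; a lower number here means that less of the compound is left, a higher number that more of the compound is left:

compound 1 `COc1cc(-c2cnn3cc(OC)c(C)nc23)ccn1` gives 44%
compound 2 `CNc1nc2c(-c3ccnc(OC)c3)cnn2cc1OC` gives 63%
compound 3 `COc1cc(-c2cnn3cc(OC)c([C@H]4COC(C)(C)C4)nc23)ccn1` gives 21%

Among these three, compound 3 stands lowest: the nearest value is that of compound 1, and the furthest is that of compound 2, both beyond the scatter. Compound 4 `COc1cc(-c2cnn3cc(OC)c(N(C)C)nc23)ccn1` has not yet been measured. It differs from compound 3 in one place: a group of 3 heavy atoms (2 carbon, 1 nitrogen; no ring) in place of a group of 7 heavy atoms (6 carbon, 1 oxygen; one five-membered non-aromatic ring with 1 hetero atom), on an aromatic carbon.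

Two measured steps speak to this change. The step of a number 42 percentage points lower from compound 2 to compound 3 (beyond the scatter) shows what happens when the five-membered ring group replaces a small nitrogen-containing group on this aromatic carbon; the step of a number 23 percentage points lower from compound 1 to compound 3 (beyond the scatter) shows the same group replacing a methyl. The change from compound 3 to compound 4 runs the other way, removing that ring group and putting in a small nitrogen-containing group. Going by these compounds, a rise in this assay is therefore expected, roughly the reverse of the large step seen from compound 2 to compound 3, though the dimethylamino group itself is untested here. For compound 4, a step of a number 34 percentage points higher from compound 3 to compound 4 (beyond the scatter) is expected, giving an estimated 55% with a range from 35% to 75%.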

Compound 4, percent of the compound remaining: 16%
Beside the measured number, compound 4's estimate is 39 percentage points above it, and the stated range ends above it.
By their numbers in this assay, from the lowest: compounds 4 and 3 (each within the scatter of the next); then compound 1; then compound 2.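

In this assay the small dimethylamino group and the larger ring group on this aromatic carbon cannot be told apart (a number 5 percentage points lower from compound 3 to compound 4 (within the scatter)), so a small nitrogen-containing group here does not by itself go with more compound left. A single methyl on the nitrogen separates the two amines (a number 47 percentage points lower from compound 2 to compound 4 (beyond the scatter)), and dimethylamino also falls short of a plain methyl at this position (a number 28 percentage points lower from compound 1 to compound 4 (beyond the scatter)). No measurement in hand explains why one added methyl makes this difference.

Still open, going by these compounds, is how an unsubstituted amino group, an ethylamino group or a ring amine such as morpholine would behave on this aromatic carbon. Also open, on these data alone, is whether adding a methyl to the nitrogen would give a similar step on a different core.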